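A few compounds are considered here, and "the series" means these few. Any claim that something is new, unique, unknown or untested is made for them only; others in the source may bear on it.

In an ADME assay on MCF7-DOX cells (Homo sapiens) for cytotoxicity, read by MTT assay, with a stated time of 48 h (on this read-out lower numbers stand for stronger inhibition and higher numbers for weaker inhibition), compound 2 `COc1cc(O)c(C(=O)/C=C/c2cccc(N3CCNCC3)c2)c(OC)c1` gives 99200 nM. That number lies within the usual scatter of compound 1 `COc1cc(OC)c(C(=O)/C=C/c2ccc(C(F)(F)F)cc2)c(O)c1CC=C(C)C`, at 73700 nM, and of compound 3 `COc1cc(OC)c(C(=O)/C=C/c2cccc(C(F)(F)F)c2)c(O)c1CC=C(C)C`, at 66600 nM. So the three compounds cannot be ranked on these numbers.

Compound 4 `COc1cc(OC)c(C(=O)/C=C/c2cccc(N3CCNCC3)c2)c(O)c1C` differs from compound 2 by one small edit: methyl in place of hydrogen on an aromatic carbon. Within the data shown here, no measured pair shows this change directly. Among the measured compounds shown here, the only measured step, a 1.1-fold lower number from compound 1 to compound 3 (0.04 log units; within the scatter), moves a trifluoromethyl group and stays within the scatter, so it bears on the methyl only indirectly. It does show that a change of place on the shared framework left the number where it was, and compounds 1 and 3 also differ from compound 2 in more than one place without leaving the scatter.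

The expected step is small, a 1.4-fold lower number from compound 2 to compound 4 (0.15 log units; within the scatter), not beyond the scatter, and the slight lean towards a lower number has no measurement behind it. For compound 4 the estimated value is 70000 nM, with an expected range from 30000 nM to 130000 nM.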

Compound 4, half-maximal inhibitory concentration: 98700 nM
Compound 4: the middle estimate sits 1.4-fold (0.15 log units) below what was measured; low and high end bracket the measured number.
By their numbers in this assay, from the lowest: compounds 3, 1, 4 and 2 (each within the scatter of the next).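

In this assay, the pair of compounds now gives a direct reading of this change, a 1.0-fold lower number from compound 2 to compound 4 (0.00 log units; within the scatter), which stays within the scatter. The earlier compounds shown here included no such pair, whereas this one shows that a methyl in place of hydrogen on this aromatic carbon, ortho to a hydroxy group and to a methoxy group and para to a methoxy group, leaves the number where it stood.

This single pair cannot tell whether other groups on the same carbon would behave alike, such as an amine, a carboxylic acid or a chlorine atom. It also leaves open whether the methyl would make as little difference on a compound carrying a trifluoromethyl group in place of the piperazine. No measurement shown here accounts for this result.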